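This account rests on a few compounds, and the source may have more. Where it says the series, first, only, none or still open, it means among the compounds named here.

Compound 1 `CC1CCN(C2CCN(S(=O)(=O)c3cn(C)cn3)CC2)CC1` was tested in a functional assay on DLD-1 cells (Homo sapiens) for antiproliferative activity, read by CellTiter-Glo, with a stated time of 72 h; a lower number here means a stronger inhibitor, a higher number a weaker inhibitor. Compound 1 gives > 5000 nM in this assay, which is a limit of the assay and not a number; among the three values shown, it is the one at the limit of > 5000 nM in this assay, at which 1 of the 3 values shown sits. Two other compounds built on the shared core do give numbers. Compound 2 `CC1CCCN(C2CCN(S(=O)(=O)c3ccc(OC(F)F)cc3)CC2)C1` gives 105 nM in this assay. Compound 3 `CC(=O)Nc1ccc(S(=O)(=O)N2CCC(N3CCC(C)CC3)CC2)c2ccccc12` gives 1100 nM in this assay. No two of these compounds differ in one place only, so no single measured step can be drawn between them; what the values show is that compound 2 and compound 3 both give numbers where compound 1 does not.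

Compound 4 `CC1CCN(C2CCN(S(=O)(=O)c3ccc(C#N)cc3)CC2)CC1` has not yet been measured in this assay. It differs from compound 1 by 4-cyanophenyl in place of 1-methyl-1H-imidazol-4-yl on a sulfonyl sulfur. Because compound 1 sits at the limit of > 5000 nM in this assay, at which 1 of the 3 values shown sits, the step to compound 4 can only be stated as an expectation: compound 4 is expected to be a stronger inhibitor, by a step well beyond the scatter, as an at least 16-fold lower number from compound 1 to compound 4 (1.22 log units; beyond the scatter). Compound 4 is estimated at 300 nM, with a range from 80 nM to 1500 nM.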

Compound 4, half-maximal inhibitory concentration: 2800 nM
Compound 4: middle estimate off by 9.3-fold (0.97 log units), on the low side; the measured number lies above the stated range.
By their numbers in this assay, from the lowest: compound 2; then compound 3; then compound 4. At a limit, above all of these: compound 1.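

In this assay, 4-cyanophenyl in place of 1-methyl-1H-imidazol-4-yl on a sulfonyl sulfur gives an at least 1.7-fold lower number from compound 1 to compound 4 (0.25 log units; that floor lies within the scatter). Going by these compounds alone, this is the first step between compounds that differ in one place, but its true size cannot be read, as the value of compound 1 is a limit of the assay and not a number: the limit of > 5000 nM in this assay, at which 1 of the 4 values shown sits. What it adds is that this one change at the sulfonyl sulfur turns a limit into a number, though it does not establish a step beyond the scatter.

The compounds shown leave open whether a plain phenyl, or a 4-substituted phenyl carrying a carboxylic acid or an amine in place of the nitrile, would give a lower number on the otherwise unchanged core of compound 4. Compound 2 and compound 3 differ from compound 4 in more than one place, so they cannot settle this.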